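Moving Two Fluorines Around the Same Phenyl Ring

The source may report more compounds than this note shows. Statements on the series, on what has been measured and on what is new or still open speak of the compounds shown alone.

Compound 1 `Nc1scc(CN2CCN(c3ccc(OC(F)(F)F)cc3)CC2)c1C(=O)c1ccc(Cl)cc1`: 0%
Compound 2 `Nc1scc(CN2CCN(c3ccc(F)c(F)c3)CC2)c1C(=O)c1ccc(Cl)cc1`: -3.2%

Both compounds share one core and differ only in the aryl group on the piperazine-type nitrogen. In a functional assay on CHO cells with adenosine receptor A1 (Homo sapiens) as the target, read by cAMP accumulation and immunoassay, with a stated time of 6 min, tested at 0.01 uM (a higher number here means a weaker effect of the compound at the concentration tested, a lower number a stronger effect), compound 1 gives 0%, and compound 2 gives -3.2%. Compound 2 has the lower of the two numbers, but the step of a number 3.2 percentage points lower from compound 1 to compound 2 (within the scatter) is within the scatter, so the two cannot be told apart.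

Compound 3 `Nc1scc(CN2CCN(c3c(F)cccc3F)CC2)c1C(=O)c1ccc(Cl)cc1` has not yet been measured. Its difference from compound 2 is 2,6-difluorophenyl in place of 3,4-difluorophenyl on an amine nitrogen in a ring. Among the compounds with values here, the only measured step that bears on this position, a number 3.2 percentage points lower from compound 1 to compound 2 (within the scatter), was within the scatter, so the numbers give no reason to expect a change beyond the scatter here either. The expected step is a number 2.2 percentage points higher from compound 2 to compound 3 (within the scatter). Compound 3 is therefore estimated to give -1% in this assay, with a likely range from -12% to 10%.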

Compound 3, a percentage reported as activity, at one concentration (the size of the read-out at that concentration, not a potency): -12%
Compound 3: middle estimate off by 11 percentage points, on the high side, and the stated range covers the measured number.
By their numbers in this assay, from the lowest: compounds 3, 2 and 1 (each within the scatter of the next, the first and the last beyond it).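

Exchanging 3,4-difluorophenyl for 2,6-difluorophenyl on the ring amine nitrogen gives a number 8.8 percentage points lower from compound 2 to compound 3 (within the scatter) in this assay and so leaves the two isomers indistinguishable, even though the same atoms are joined differently. Within the data shown here, the replacement of 4-(trifluoromethoxy)phenyl by 2,6-difluorophenyl gives a number 12 percentage points lower from compound 1 to compound 3 (beyond the scatter) and is the first step here to clear the scatter, showing that a change of aryl group at this nitrogen can modestly strengthen the effect at the concentration tested. No measurement available here accounts for that step.

The compounds shown leave open whether a phenyl ring bearing a single fluorine, a methoxy group or a nitrile would behave like compound 3 or like compound 1. They also leave open how a pyridine ring in place of the phenyl ring would read in this assay.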